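Effect of removing a chain ethyl branch on lung inhibition

The source may report more compounds than this note shows. Statements on the series, on what has been measured and on what is new or still open speak of the compounds shown alone.

Measured compounds in a functional assay (lung) for inhibition, with Cavia porcellus as the target; on this read-out higher numbers stand for weaker inhibition and lower numbers for stronger inhibition:
compound 1 `CCCC(CCC(=O)O)Cc1ccc(OCc2ccc3ccccc3n2)cc1` gives 30 nM
compound 2 `CC(CCC(=O)O)Cc1ccc(OCc2ccc3ccccc3n2)cc1` gives 100 nM
compound 3 `CCCC(CCc1nnn[nH]1)Cc1cccc(OCc2ccc3ccccc3n2)c1` gives 16 nM

Compound 1 and compound 2 share a core and differ in one place: hydrogen in place of ethyl on a saturated chain carbon, three bonds along the chain from an aromatic carbon. This change gave a 3.3-fold higher number from compound 1 to compound 2 (0.52 log units; beyond the scatter) in this assay. Compound 3 has a different core, and the difference between the two cores is not broken down here; compound 3 and compound 1 lie within the scatter of each other in this assay, while compound 2 reads higher than both.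

Compound 4 `CC(CCc1nnn[nH]1)Cc1cccc(OCc2ccc3ccccc3n2)c1` is not yet measured. It differs from compound 3 by hydrogen in place of ethyl on a saturated chain carbon, three bonds along the chain from an aromatic carbon, which is the same change as that from compound 1 to compound 2, at the same place. The expectation rests on that single earlier step: compound 4 is estimated to show a 3.1-fold higher number from compound 3 to compound 4 (0.49 log units; beyond the scatter) in this assay, carrying over the size of a 3.3-fold higher number from compound 1 to compound 2 (0.52 log units; beyond the scatter). Among the compounds with values here, the core of compound 3 is different from that of compound 1 and compound 2, and only one example of the change exists. The estimate is therefore held loosely. Compound 4 is expected at about 50 nM, between 20 nM and 130 nM.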

Compound 4, half-maximal inhibitory concentration: 150 nM
Compound 4: middle estimate off by 3.0-fold (0.48 log units), on the low side; measured number outside the range, above it.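

In this assay the change from propyl to methyl gives a 9.4-fold higher number from compound 3 to compound 4 (0.97 log units; beyond the scatter) on the core of compound 3, the same direction as on the core of compound 1. The direction of the change therefore held on both cores shown, while its size did not carry over from one core to the other: the same change on two cores in this assay, a 3.3-fold higher number (0.52 log units; beyond the scatter) from compound 1 to compound 2 and a 9.4-fold higher number (0.97 log units; beyond the scatter) from compound 3 to compound 4, 2.8-fold (0.45 log units) apart, beyond the scatter of two such steps

The two cores differ in more than one place, so these two pairs cannot show which part of that difference goes with the larger step, and they give no basis for predicting the size of the step on a third core.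

Still open is how the number responds to the chain at this carbon beyond the two ends shown, for example with an ethyl group in place of propyl, or with a longer chain such as butyl on either core. Also open, going by these compounds, is whether a cyclopropyl group at the same place would keep the lower numbers seen with propyl.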